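Bromo to Methoxycarbonyl on the Benzyl Group

A few compounds are considered here, and "the series" means these few. Any claim that something is new, unique, unknown or untested is made for them only; others in the source may bear on it.

Compounds with results: compound 3 (`O=c1c2cnn(-c3ccc(F)cc3)c2ncn1CC1(O)CCN(Cc2ccc(Br)cc2)CC1`), 6700 nM in an assay on Sf21 cells for inhibition of ubiquitin carboxyl-terminal hydrolase 7 (Homo sapiens), read by spectrophotometry, with stated times of 30 min and 2 h; a higher number here means a weaker inhibitor, a lower number a stronger inhibitor. Compound 1 (`O=c1c2cnn(-c3ccc(F)cc3)c2ncn1CC1(O)CCN(Cc2cccnc2)CC1`) carries "not determined" (no result reported) in this assay, and compound 2 (`COC(=O)C(c1ccccc1Cl)N1CCC(O)(Cn2cnc3c(cnn3-c3ccc(F)cc3)c2=O)CC1`) likewise carries "not determined" (no result reported) in this assay.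

Compound 3 therefore stands alone on the numbers shown: its half-maximal inhibitory concentration, 6700 nM, is the only value available, and it marks a weak inhibitor, with nothing beside it for comparison.

Compound 4 (`COC(=O)c1ccc(CN2CCC(O)(Cn3cnc4c(cnn4-c4ccc(F)cc4)c3=O)CC2)cc1`) differs from compound 3 in one place: methoxycarbonyl in place of bromo on an aromatic carbon. In words, a methoxycarbonyl enters in place of the bromo on an aromatic carbon of the six-membered aromatic ring of carbon only, para to a large group.

Going by the values given here, no measured pair in this set shows what such a change does. The step from compound 3 to compound 4 in this assay is expected to lie within the usual scatter, with at most a slight drift toward weaker inhibition, so the expected step is a 1.2-fold higher number from compound 3 to compound 4 (0.08 log units; within the scatter). For compound 4 the estimate in this assay is 8000 nM, within a range of 3000 nM to 25000 nM.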

Compound 4, half-maximal inhibitory concentration: 4500 nM
Compound 4: the middle estimate sits 1.8-fold (0.25 log units) above what was measured, within the range that was stated.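

In this assay, going by these compounds alone, replacing bromo with methoxycarbonyl on the aromatic carbon para to a large group gives a 1.5-fold lower number from compound 3 to compound 4 (0.17 log units; within the scatter) and is the first measured step at this position. It shows that this place on the ring can carry either a single bromine or a methoxycarbonyl of 4 heavy atoms with 2 hydrogen-bond acceptors, while the number stays within the scatter. No evidence accompanying these compounds bears on the reason for this result.

On these data alone, it remains open whether a carboxylic acid, an amine or a longer chain at this same place would move the number beyond the scatter. As far as these compounds go, it is also open whether methoxycarbonyl would give a similar result elsewhere on this ring.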